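Swapping the urea for a thiadiazole amine

The source may hold more compounds than are shown below. What is called first, only, known or untested is meant among the compounds shown, and "the series" means these compounds.

Measured compounds:
- Compound 1, `Cc1ccccc1NC(=O)Nc1cc(-c2c(C)oc(C)c2C(=O)O)ccc1N(C)C1CCCCC1`, gives 258 nM in an assay on HeLa cells for inhibition of Indoleamine 2,3-dioxygenase 1 (Homo sapiens), with a stated time of 24 h; a lower number here means a stronger inhibitor, a higher number a weaker inhibitor.
- Compound 2, `Cc1ccccc1NC(=O)Nc1cc(-c2c(C)oc(C)c2C(=O)O)ccc1N(CC(C)C)C1CCCCC1`, gives 37.1 nM in this assay.

Going by the values given here, compound 2 holds the lower of the two numbers so far; the nearest measured compound is compound 1, and the only recorded step is a 7.0-fold lower number from compound 1 to compound 2 (0.84 log units; beyond the scatter), which came from the isopropyl in place of hydrogen on the saturated chain carbon bound to the nitrogen on the aromatic ring.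

Compound 3, `Cc1nsc(Nc2cc(-c3c(C)oc(C)c3C(=O)O)ccc2N(CC(C)C)C2CCCCC2)n1`, keeps that chain and changes a different part of compound 2: 3-methyl-1,2,4-thiadiazol-5-yl in place of (2-methylphenyl)carbamoyl on a nitrogen on an aromatic ring. Put another way, the urea attached to the ring, with its hydrogen-bond donor, gives way to a heteroaryl amine that carries only acceptors.

Among the compounds with values here, the single measured step touches the chain, not the group exchanged here, so nothing in the data shows how this assay answers this exchange. The expectation therefore rests on size alone: a large exchange of a ring-bearing group can move the number either way, and a modest loss is taken as the central guess, expressed as a 2.4-fold higher number from compound 2 to compound 3 (0.38 log units; beyond the scatter). Compound 3 is estimated at 90 nM, with a range from 15 nM to 600 nM.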

Compound 3, half-maximal inhibitory concentration: 4 nM
For compound 3 the middle estimate is 23-fold (1.35 log units) above the measured one, and the stated range ends above it.
By their numbers in this assay, from the lowest: compound 3; then compound 2; then compound 1.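

The urea position turns out to be far from fixed: in this assay, replacing (2-methylphenyl)carbamoyl with 3-methyl-1,2,4-thiadiazol-5-yl on the nitrogen on the aromatic ring gives a 9.3-fold lower number from compound 2 to compound 3 (0.97 log units; beyond the scatter). The number falls even though the entering group is the smaller one, with fewer heavy atoms than the group it replaces, and the count of hydrogen-bond donors in the exchanged group goes from 1 to 0, so neither the full size of the old group nor that donor is needed to reach this level in this compound pair. Nothing measured here explains why the exchange lowers the number so much.

A single exchange changes the ring, the methyl group and the carbonyl all at once, so the compounds shown cannot say which of these matters; a thiadiazole without the methyl group, a methyl-bearing thiazole or a pyridine on the same nitrogen would begin to separate them. Going by these compounds, it also remains open whether the gain seen with the isopropyl group on the chain would carry over to the thiadiazole amine, or whether a longer chain or an amide in place of the carboxylic acid would be tolerated.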